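The source may report more compounds than this note shows. Statements on the series, on what has been measured and on what is new or still open speak of the compounds shown alone.

Compound 2 `Cc1cc(C)c(S(=O)(=O)N2CCC(N3CCC(C(C)C)CC3)CC2)c(C)c1` holds the lowest of the two numbers in a functional assay on DLD-1 cells (Homo sapiens) for antiproliferative activity, read by CellTiter-Glo, with a stated time of 72 h (a lower number here means a stronger inhibitor, a higher number a weaker inhibitor), at 0.3 nM. Within the data shown here, its only measured neighbour is compound 1 `Cc1cc(C)c(S(=O)(=O)N2CCC(N3CCC(CCO)CC3)CC2)c(C)c1`, which in this assay gives 19 nM. Among the measured compounds shown here, the one step between them, a 63-fold lower number from compound 1 to compound 2 (1.80 log units; beyond the scatter), is the single comparison available. Compound 3 `Cc1cc(C)c(S(=O)(=O)N2CCC(N3CCC(Cc4ccccc4F)CC3)CC2)c(C)c1` differs from compound 2 in one place: 2-fluorobenzyl in place of isopropyl on a saturated ring carbon. For the measured compounds named here, no measured step covers an exchange of this kind: the known step, a 63-fold lower number from compound 1 to compound 2 (1.80 log units; beyond the scatter), concerned a 2-hydroxyethyl giving way to an isopropyl, a different pair of groups, and so it gives only weak guidance on what a 2-fluorobenzyl does at the same saturated ring carbon. For compound 3 a modest step of a 3.3-fold higher number from compound 2 to compound 3 (0.52 log units; beyond the scatter) toward a higher number is expected, with wide uncertainty. The estimate for compound 3 is 1 nM, within a range from 0.15 nM to 8 nM.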

Compound 3, half-maximal inhibitory concentration: 74 nM
Compound 3: middle estimate off by 74-fold (1.87 log units), on the low side; measured number outside the range, above it.
By their numbers in this assay, from the lowest: compound 2; then compound 1; then compound 3.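

At this saturated ring carbon the outcome in this assay turns out to be highly sensitive to the group, and a larger group with a six-membered aromatic ring does not carry the low number of the isopropyl, with a 250-fold higher number from compound 2 to compound 3 (2.39 log units; beyond the scatter). Both the isopropyl and the 2-fluorobenzyl count no hydrogen-bond donors or acceptors, so that shared count does not secure a low number, and the 2-fluorobenzyl even ends up past the 2-hydroxyethyl, with a 3.9-fold higher number from compound 1 to compound 3 (0.59 log units; beyond the scatter). No measurement at hand explains these differences. The compounds shown leave open whether the loss follows from the aromatic ring, the fluorine or the added size alone, which a plain benzyl could begin to separate. They also leave open how tightly the low number is tied to isopropyl itself, as against a cyclopropyl or a tert-butyl at the same carbon.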